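Swapping the ring on a long-chain phosphate

A few compounds are considered here, and "the series" means these few. Any claim that something is new, unique, unknown or untested is made for them only; others in the source may bear on it.

Compound 1 `CCCCCCCCCCCCCCCCOP(=O)(O)OCCSC(=S)N1CCN(C)CC1` gives > 100000 nM
Compound 2 `CCCCCCCCOP(=O)(O)OCCSC(=S)N1CCN(C)CC1` gives 46000 nM

In a functional assay on MCF7 cells (Homo sapiens) for inhibition, read by MTT assay, with stated times of 18 h and 4 h (on this read-out lower numbers stand for stronger inhibition and higher numbers for weaker inhibition), compound 1 gives only a limit (> 100000 nM), not a number. Compound 3 `CCCCCCCCCCCCCCCCOP(=O)(O)OCCSC(=S)N1CCCC1` keeps the chain of compound 1 but carries pyrrolidin-1-yl in place of 4-methylpiperazin-1-yl on a thiocarbonyl carbon. For the measured compounds named here, the only measured step (an at least 2.1-fold lower number from compound 1 to compound 2 (0.33 log units; beyond the scatter)) shortens the chain and leaves this group untouched, so it gives no direct guide to the size of this change. In this assay a small move to lower numbers is expected (an at least 1.6-fold lower number from compound 1 to compound 3 (0.22 log units; that floor lies within the scatter)). For compound 3 the estimated value is 60000 nM (range 15000 nM to 150000 nM), and the result may again be only a limit.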

Compound 3, half-maximal inhibitory concentration: 72000 nM
Compound 3: the middle estimate sits 1.2-fold (0.08 log units) below what was measured; measured number inside the range.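

In this assay compound 1 gives only a limit, > 100000 nM. Pyrrolidin-1-yl in place of 4-methylpiperazin-1-yl on a thiocarbonyl carbon gives an at least 1.3-fold lower number from compound 1 to compound 3 (0.14 log units; that floor lies within the scatter), so this change need not be a real one, though the true step could be larger. This first look at the position therefore sets no firm size for the change, because one end of the comparison is not a number: the limit of > 100000 nM in this assay, at which 1 of the 3 values shown sits.

Going by these compounds, it remains open whether piperidin-1-yl or morpholin-4-yl on this carbon would give lower numbers. On these data alone, it is also open whether pyrrolidin-1-yl would shift the value of compound 2, with its shorter chain.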